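Sulfonyl Extension on a Nitro Core and Liver-Cell Toxicity

The source may hold more compounds than are shown below. What is called first, only, known or untested is meant among the compounds shown, and "the series" means these compounds.

Compound 1 `Cc1nc2c(Sc3ccc(Cl)cc3)cc(Cl)cn2c1[N+](=O)[O-]`: > 7800 nM in an ADME assay on HepG2 cells (Homo sapiens) for cytotoxicity, read by MTT assay, with a stated time of 72 h; on this read-out higher numbers stand for lower toxicity in this test and lower numbers for higher toxicity in this test
Compound 2 `O=[N+]([O-])c1c(CS(=O)(=O)c2ccccc2)nc2c(Br)cc(C(F)(F)F)cn12`: > 15600 nM in this assay

For compound 1 the reported value > 7800 nM is a limit of this assay, not a number, so it sits at the limit of > 7800 nM in this assay, at which 1 of the 2 values shown sits. For compound 2 the value > 15600 nM is likewise a limit, at the limit of > 15600 nM in this assay, at which 1 of the 2 values shown sits. Among the measured compounds shown here, both values show only that neither compound reached half-maximal toxicity within the tested range; with two limits, no order between them can be read.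

Compound 3 `O=[N+]([O-])c1c(CS(=O)(=O)c2cccnc2)nc2c(Sc3ccc(Cl)cc3)cc(Cl)cn12` is not yet measured. It differs from compound 1 by (pyridin-3-yl)sulfonyl in place of hydrogen on a saturated chain carbon bound to an aromatic carbon. For the measured compounds named here, no measured pair shows this change directly. For compound 3 the step that the limit leaves unreadable from compound 1 to compound 3 is expected to be none beyond the usual scatter, with the value most likely again a limit. The estimate for compound 3 in this assay is 15000 nM, with a range from 5000 nM to 40000 nM.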

Compound 3, half-maximal cytotoxic concentration: > 31200 nM
Compound 3 ended at the assay's limit; the forecaster's own chance of this, stated with the estimate: 75%; middle value at least 2.0-fold (0.31 log units) from the limit.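

Among the compounds shown here, compound 1 and compound 3 both sit at limits of the test rather than at numbers, so no step between them can be read. Going by these compounds, whether (pyridin-3-yl)sulfonyl in place of hydrogen changes anything in this assay stays open, as does the true half-maximal concentration of either compound.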